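Trifluoromethoxy to methyl in the series

The compounds below may be only part of what the source reports. "The series", "measured", "known", "first", "only" and "open" are said of these compounds alone.

Measured so far in a functional assay on MDA-MB-231 cells (Homo sapiens) for antiproliferative activity, read by MTT assay, with a stated time of 72 h; a higher number here means a weaker inhibitor, a lower number a stronger inhibitor 
compound 1 `O=S1(=O)C=Cc2ccc(Nc3ccc(F)c(F)c3)cc21` gives 3050 nM 
compound 2 `O=S1(=O)C=Cc2cccc(Nc3ccc(OC(F)(F)F)cc3)c21` gives 2100 nM 

Compound 1 and compound 2 lie within the scatter of each other, and neither ranks ahead. Compound 3 `Cc1ccc(Nc2cccc3c2S(=O)(=O)C=C3)cc1`, not yet measured, has methyl in place of trifluoromethoxy on an aromatic carbon, para to a large group (methyl in place of trifluoromethoxy on an aromatic carbon). No measured step sizes this change. Going by these compounds, no shift beyond the scatter is expected in this assay, and the direction stays open. The estimated change (a 1.3-fold higher number from compound 2 to compound 3 (0.12 log units; within the scatter)) is expected to stay within the scatter. For compound 3 the estimated value is 2800 nM (expected range 900 nM to 8000 nM).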

Compound 3, half-maximal inhibitory concentration: 1560 nM
For compound 3 the middle estimate is 1.8-fold (0.25 log units) above the measured one, within the range that was stated.
By their numbers in this assay, from the lowest: compounds 3, 2 and 1 (each within the scatter of the next).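

Methyl in place of trifluoromethoxy, on an aromatic carbon para to a large group, gives a 1.3-fold lower number from compound 2 to compound 3 (0.13 log units; within the scatter) in this assay and is the first measured size for this change. At this position, the group can therefore shrink from trifluoromethoxy to methyl without a shift beyond the scatter in this read-out. No available evidence bears on this result.

Going by these compounds, whether an amine or a carboxylic acid at this position would shift the number beyond the scatter remains open. So does the outcome for a longer chain.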